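Fluoro to trifluoromethyl on the aryl imidazoline core

The source may report more compounds than this note shows. Statements on the series, on what has been measured and on what is new or still open speak of the compounds shown alone.

Among the measured compounds shown here, compound 1 `CS(=O)(=O)c1ccc(F)cc1NCC1=NCCN1` gives the higher of the two numbers measured so far in a functional assay for agonist activity at Alpha-1A adrenergic receptor (Homo sapiens) (a higher number here means a larger maximal response, a lower number a smaller maximal response), namely 96%; compound 2 `CSc1ccc(F)cc1NCC1=NCCN1` gives 90%, and the step of a number 6 percentage points lower from compound 1 to compound 2 (within the scatter) lies within the scatter, so the two compounds cannot be ordered. Compound 3 `CS(=O)(=O)c1ccc(C(F)(F)F)cc1NCC1=NCCN1` differs from compound 1 in one place: trifluoromethyl in place of fluoro on an aromatic carbon. For the measured compounds named here, the only measured step concerns the exchange of methylsulfonyl for methylsulfanyl, not the group changed here, so no measured step bears directly on this change; it shows only that one exchange on the aromatic ring left the maximal response unchanged within the scatter. With nothing pointing either way, the expected step is a number 6 percentage points lower from compound 1 to compound 3 (within the scatter), none beyond the scatter. Compound 3 is therefore estimated at 90% in this assay, with a range from 70% to 105%.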

Compound 3, largest response reached (reported as maximum), in percent of the reference or control that the assay uses: 95%
Compound 3: the middle estimate sits 5 percentage points below what was measured; the measured number falls inside the stated range.
By their numbers in this assay, from the lowest: compounds 2, 3 and 1 (each within the scatter of the next).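

At the aromatic carbon para to the methylsulfonyl group, trifluoromethyl in place of fluoro gives a number 1 percentage points lower from compound 1 to compound 3 (within the scatter) in this assay, so a group of 4 heavy atoms replaces one of 1 heavy atom with no change in maximal response beyond the scatter. The earlier step concerned only the methylsulfonyl group, and this is the first step read at the fluoro position; both steps shown lie within the scatter. Nothing available bears on a reason for this result.

Open, from the compounds shown here alone, is what an amine, a carboxylic acid or a longer alkyl chain at this carbon would do to the maximal response. Also open, going by these compounds, is whether trifluoromethyl in place of fluoro gives a similar step when methylsulfanyl stands in place of methylsulfonyl, and how much compound each maximal response requires.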